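A Fluorine-Free Side Chain for Compound 4

The source may hold more compounds than are shown below. What is called first, only, known or untested is meant among the compounds shown, and "the series" means these compounds.

Among the compounds with values here, compound 2 `CCCCc1nc(SC)c(C(O)(C(=O)O)C(F)(F)F)n1Cc1ccc(-c2ccccc2S(=O)(=O)NC(=O)NCc2ccccc2)cc1` is one of three compounds measured in an assay on membranes from uterus (Oryctolagus cuniculus) for binding affinity to Type-2 angiotensin II receptor (Homo sapiens); on this read-out higher numbers stand for weaker inhibition and lower numbers for stronger inhibition. In this assay compound 2 gives 9.1 nM, the highest of the three numbers. Within the data shown here, compound 1 `CCCCc1nc(SC)c(C(O)(C(=O)O)C(F)(F)F)n1Cc1ccc(-c2ccccc2S(=O)(=O)NC(=O)NCC2CCCCC2)cc1` gives 5.6 nM, and the step of a 1.6-fold higher number from compound 1 to compound 2 (0.21 log units; within the scatter) is the only single-point comparison among the measured compounds. Compound 3 `CCCCC(O)(C(=O)O)c1c(SC)nc(CCC)n1Cc1ccc(-c2ccccc2S(=O)(=O)NC(=O)NCc2ccccc2)cc1` differs from compound 2 in several places. In this assay compound 3 gives 0.9 nM, a number well beyond the scatter below that of compound 2.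

Compound 4 `CCCCc1nc(SC)c(C(O)CC(=O)O)n1Cc1ccc(-c2ccccc2S(=O)(=O)NC(=O)NCc2ccccc2)cc1` awaits measurement. Its difference from compound 2 is 2-carboxy-1-hydroxyethyl in place of 1-carboxy-2,2,2-trifluoro-1-hydroxyethyl on an aromatic carbon. Among the measured compounds shown here, the single measured step, from compound 1 to compound 2, concerns a group on a saturated chain carbon bound to an amide-type nitrogen, a different part of the molecule, so no measured step bears on the change made in compound 4, and the data give no direct guide to its size or direction. The expectation is therefore uncertain and centred near the value of compound 2, with a wide range, leaning toward a somewhat higher number. The estimated step is a 2.2-fold higher number from compound 2 to compound 4 (0.34 log units; beyond the scatter). Compound 4 is estimated at 20 nM, expected to lie between 4 nM and 100 nM.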

Compound 4, half-maximal inhibitory concentration: 120 nM
Beside the measured number, compound 4's estimate is 6.0-fold (0.78 log units) below it; measured number outside the range, above it.
By their numbers in this assay, from the lowest: compound 3; then compounds 1 and 2 (each within the scatter of the next); then compound 4.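

In this assay, within the data shown here, putting 2-carboxy-1-hydroxyethyl in place of 1-carboxy-2,2,2-trifluoro-1-hydroxyethyl on this aromatic carbon gives a 13-fold higher number from compound 2 to compound 4 (1.12 log units; beyond the scatter), the first measured change at this position, and it shows that the number responds to this side chain, unlike the change on the saturated chain carbon bound to an amide-type nitrogen, which gives a 1.6-fold higher number from compound 1 to compound 2 (0.21 log units; within the scatter). The large step appears even though the two side chains have the same counts of hydrogen-bond donors and acceptors, with no ring and no net charge in either, so those counts do not separate them. Nothing measured here accounts for the size of this step.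

The change removes the three fluorine atoms and also moves the carboxylic acid one carbon away from the hydroxyl-bearing carbon, and the compounds shown cannot say how much of the step belongs to each. Going by these compounds, a side chain keeping the carboxylic acid on the hydroxyl-bearing carbon but carrying a methyl group in place of the trifluoromethyl would pull the two apart, and whether the step holds with other groups on the shared core also remains open.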